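Swapping Bromo for Trifluoromethyl in a Deacetylase Series

The compounds below may be only part of what the source reports. "The series", "measured", "known", "first", "only" and "open" are said of these compounds alone.

Measured so far:
- compound 1, `O=C(NO)c1ccc(NCc2nc(-c3ccc(Br)cc3)nn2-c2ccccc2)cc1`: 54.7%
- compound 2, `Cc1ccccc1-n1nc(-c2ccccc2)nc1CNc1ccc(C(=O)NO)cc1`: 57.1%
- compound 3, `NNC(=O)c1ccc(NCc2nc(-c3ccccc3)nn2-c2ccccc2)cc1`: 10%

Of the compounds shown here, three have been tested in an assay on Sf9 cells for inhibition of protein deacetylase HDAC6 (Homo sapiens), read by fluorescence, with a stated time of 40 min, tested at 100 nM; a higher number here means more inhibition at the concentration tested (going by the name of the read-out), a lower number less inhibition. Compound 1 stands second highest of the three. Its nearest neighbour in number is compound 2, whose value lies within the usual scatter of compound 1, so the two cannot be told apart. Compound 3 lies far lower, beyond the scatter; it differs from compound 1 in more than one place, so only the two values themselves can be compared.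

Compound 4, `O=C(NO)c1ccc(NCc2nc(-c3ccc(C(F)(F)F)cc3)nn2-c2ccccc2)cc1`, has not yet been measured. It differs from compound 1 in a single place: trifluoromethyl in place of bromo on an aromatic carbon. Both groups entering and leaving carry no hydrogen-bond donors or acceptors and no charge, and the change sits far from the part of the molecule shared by compound 1 and compound 2, which give values within the scatter of each other.

Within the data shown here, with no measured step of this kind to lean on, the step of a number 0.3 percentage points higher from compound 1 to compound 4 (within the scatter) is expected to stay within the scatter, in no clear direction. Compound 4 is therefore estimated at 55%, with a likely range from 35% to 75%.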

Compound 4, a percentage reported as inhibition, at one concentration (the size of the read-out at that concentration, not a potency): 41.6%
The estimate for compound 4 lay 13.4 percentage points above the measured number; measured number inside the range.
By their numbers in this assay, from the lowest: compound 3; then compound 4; then compounds 1 and 2 (each within the scatter of the next).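

Until now, nothing showed whether the group on this aromatic carbon, para to a large group, matters in this assay. Trifluoromethyl in place of bromo gives a number 13.1 percentage points lower from compound 1 to compound 4 (beyond the scatter), so this position does respond to a change, even though both groups have no hydrogen-bond donors, no hydrogen-bond acceptors and no net charge. No measurement here bears on why the number changes with this swap.

This is a single step at a single test concentration, so it cannot show whether the size of the group or some other difference between the two groups matters more. A plain hydrogen, a chlorine, a methyl group or an amine at this place would help show whether bromo is a particularly good fit or trifluoromethyl a particularly poor one.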